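A few compounds are considered here, and "the series" means these few. Any claim that something is new, unique, unknown or untested is made for them only; others in the source may bear on it.

Measured compounds:
compound 1, `Nc1ncnc2c1nc(NCc1cccc(Cl)c1)n2[C@@H]1O[C@H](CO)[C@@H](O)[C@H]1O`, 5400 nM
compound 2, `CCOC(=O)OC[C@H]1O[C@@H](n2cnc3c(N)ncnc32)[C@H](O)[C@@H]1O`, > 100000 nM
compound 3, `CCCCCC(=O)OC[C@H]1O[C@@H](n2cnc3c(N)ncnc32)[C@H](O)[C@@H]1O`, > 100000 nM

Going by the values given here, in an assay on COS-7 cells for inhibition of sodium/nucleoside cotransporter 2 (Homo sapiens), read by scintillation counting, in the presence of a further agent that is not named here (a higher number here means a weaker inhibitor, a lower number a stronger inhibitor), compound 1 gives 5400 nM, the only number among the three values shown. Compound 2 gives only a limit, > 100000 nM. Compound 3 likewise gives only a limit, > 100000 nM. The step that the two limits leave unreadable from compound 2 to compound 3 cannot be read, because of the limit of > 100000 nM in this assay, at which 2 of the 3 values shown sit. So compound 1 stands alone as the one compound with a measured number in this assay.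

Compound 4, `Nc1ncnc2c1nc(NCc1ccc(Cl)cc1)n2[C@@H]1O[C@H](CO)[C@@H](O)[C@H]1O`, differs from compound 1 by 4-chlorophenyl in place of 3-chlorophenyl on a saturated chain carbon bound to a nitrogen on an aromatic ring. Among the compounds with values here, none of the measured steps touches this part of the structure: compounds 2 and 3 differ from each other on a carbonyl carbon and carry no chlorophenyl group at all, so their unreadable step gives no guidance. With nothing bearing on the change, the expected step of no change at the digits printed from compound 1 to compound 4 (within the scatter) in this assay is one of no clear size or direction beyond the usual scatter. Compound 4 is therefore estimated to give 5400 nM, with a range from 1500 nM to 20000 nM.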

Compound 4, half-maximal inhibitory concentration: 11000 nM
Estimate against measurement, compound 4: 2.0-fold (0.31 log units) below; the measured number falls inside the stated range.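

In this assay, going by these compounds alone, the pair gives the first readable step: a 2.0-fold higher number from compound 1 to compound 4 (0.31 log units; beyond the scatter) shows that this position is sensitive to where the chlorine sits on the benzyl group. The change from 3-chlorobenzyl to 4-chlorobenzyl leaves the atoms the same and joins them differently, yet compound 4 is a modestly weaker inhibitor than compound 1 and still gives a number rather than a limit. No measurement shown here accounts for this step.

The compounds shown leave open how an unsubstituted benzyl group, a methoxy group in place of the chlorine, or a longer chain such as phenethyl would read at this position. The step between compounds 2 and 3 cannot be read, and both differ from compound 1 in more than one place, so they say nothing about this position.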